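A few compounds are considered here, and "the series" means these few. Any claim that something is new, unique, unknown or untested is made for them only; others in the source may bear on it.

Measured in an ADME assay on HEp-2 cells (Homo sapiens) for cytotoxicity; on this read-out lower numbers stand for higher toxicity in this test and higher numbers for lower toxicity in this test:
Compound 1 `Cc1cccc(NC(=O)[C@@H]2CCCN2S(=O)(=O)c2cccc3cccnc23)c1` gives 25500 nM.
Compound 2 `O=C(Nc1ccc(Cl)cc1Cl)[C@@H]1CCCN1S(=O)(=O)c1cccc2cccnc12` gives only a limit of the assay, > 50000 nM.
Compound 3 `COc1ccc(C)c(NC(=O)[C@@H]2CCCN2S(=O)(=O)c2cccc3cccnc23)c1` gives 44200 nM.

Compound 1 sits at the low end of the two numbers in this assay; compound 3 is the nearest, a 1.7-fold higher number from compound 1 to compound 3 (0.24 log units; within the scatter), and compound 2 sits at the limit of > 50000 nM in this assay, at which 1 of the 3 values shown sits, so an at least 1.9-fold higher number from compound 1 to compound 2 (0.29 log units; that floor lies within the scatter) is a floor only. Compound 4 `Cc1ccc(C(C)C)cc1NC(=O)[C@@H]1CCCN1S(=O)(=O)c1cccc2cccnc12` is the next variation on the same position: 5-isopropyl-2-methylphenyl in place of 3-methylphenyl on an amide-type nitrogen. Among the compounds with values here, the only steps that bear on it are the two other swaps of the aryl group on the amide-type nitrogen, and neither moved the read-out beyond the scatter. No step beyond the scatter is expected for compound 4 either, perhaps a slightly higher number, a 1.4-fold higher number from compound 1 to compound 4 (0.14 log units; within the scatter). Compound 4 is therefore estimated at 35000 nM, with a range from 15000 nM to 80000 nM.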

Compound 4, half-maximal cytotoxic concentration: 9700 nM
Beside the measured number, compound 4's estimate is 3.6-fold (0.56 log units) above it; measured number below the stated range.
By their numbers in this assay, from the lowest: compound 4; then compounds 1 and 3 (each within the scatter of the next). At a limit, above all of these: compound 2.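

In this assay, the aryl group on the amide-type nitrogen now gives steps beyond the scatter, where the earlier swaps stayed within it: a 2.6-fold lower number from compound 1 to compound 4 (0.42 log units; beyond the scatter) and a 4.6-fold lower number from compound 3 to compound 4 (0.66 log units; beyond the scatter). The second of these is a single change, isopropyl in place of methoxy on an aromatic carbon. The third step, an at least 5.1-fold lower number from compound 2 to compound 4 (0.71 log units; beyond the scatter), is only a floor, and the value of compound 2 is a limit of the assay: the limit of > 50000 nM in this assay, at which 1 of the 4 values shown sits.

From the compounds shown here alone, whether a tert-butyl group or a longer alkyl chain in place of isopropyl would give a similar number remains open. So does the effect of an amine or a carboxylic acid on this aryl ring.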